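The source may hold more compounds than are shown below. What is called first, only, known or untested is meant among the compounds shown, and "the series" means these compounds.

Working notes on the series. In a functional assay on FM3A cells (Mus musculus) for antiproliferative activity, with a stated time of 48 h (a higher number here means a weaker inhibitor, a lower number a stronger inhibitor), compound 1 `Nc1ccc(/C=C/C(=O)c2ccccc2)cc1` gives 146000 nM, compound 2 `Nc1ccc(/C=C/C(=O)c2ccc(F)cc2)cc1` gives 185000 nM and compound 3 `Cc1ccc(C(=O)/C=C/c2ccc(N)cc2)cc1` gives 107000 nM. Compound 3 therefore stands level with the other two, with no gap beyond the scatter on either side.

The next structure is compound 4 `COc1ccc(C(=O)/C=C/c2ccc(N)cc2)cc1`, described by methoxy in place of methyl on an aromatic carbon, para to a large group. For the measured compounds named here, three measured steps also exchange a group on an aromatic carbon, and they are the only guide here: a 1.3-fold higher number from compound 1 to compound 2 (0.10 log units; within the scatter), a 1.4-fold lower number from compound 1 to compound 3 (0.13 log units; within the scatter) and a 1.7-fold lower number from compound 2 to compound 3 (0.24 log units; within the scatter). All three stay within the scatter, and none involves methoxy, so the data favour no direction. No step beyond the scatter is expected in this assay for this change. The expected step is small: a 1.2-fold higher number from compound 3 to compound 4 (0.07 log units; within the scatter). For compound 4 the estimated value is 125000 nM, with an expected range of 65000 nM to 220000 nM.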

Compound 4, half-maximal inhibitory concentration: 282000 nM
Beside the measured number, compound 4's estimate is 2.3-fold (0.35 log units) below it, and the stated range ends below it.
By their numbers in this assay, from the lowest: compounds 3, 1, 2 and 4 (each within the scatter of the next, the first and the last beyond it).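

For the compounds shown here, at this position, on an aromatic carbon para to a large group, methoxy in place of methyl is the only exchange so far that goes beyond the scatter in this assay, with a 2.6-fold higher number from compound 3 to compound 4 (0.42 log units; beyond the scatter) as the step. The other two steps to methoxy stay within the scatter, with a 1.5-fold higher number from compound 2 to compound 4 (0.18 log units; within the scatter) and a 1.9-fold higher number from compound 1 to compound 4 (0.29 log units; within the scatter) as their sizes, so methoxy separates only from methyl and not from fluoro or hydrogen. No measurement to hand bears on the origin of this step.

On these data alone, it remains open whether a hydroxy group or an ethoxy group at this place would track methoxy or methyl. A longer chain or an amine here would also show whether the separation from methyl extends beyond this one pair.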